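The source may hold more compounds than are shown below. What is called first, only, known or untested is meant among the compounds shown, and "the series" means these compounds.

Series notes. Three compounds share a core and differ in the carboxylic acid-bearing arm. Compound 1 `CCC(C(=O)O)c1nn(Cc2cn3cc(OCC4CC4)c(Cl)cc3n2)c2ccccc2c1=O` carries a 1-carboxypropyl group; in a physicochemical assay for lipophilicity, at pH 7.4 (on this read-out lower numbers stand for lower lipophilicity and higher numbers for higher lipophilicity), compound 1 gives 2.71. Compound 2 `O=C(O)C1(c2nn(Cc3cn4cc(OCC5CC5)c(Cl)cc4n3)c3ccccc3c2=O)CC1` carries a 1-carboxycyclopropyl group and in this assay compound 2 gives 2.46, the lowest of the three numbers. Compound 3 `C[C@H](C(=O)O)n1nc(Cn2cc3cc(OCC4CC4)c(Cl)cc3n2)c2ccccc2c1=O` places a 1-carboxyethyl group elsewhere on the core; in this assay compound 3 gives 2.99, which stands beyond the scatter from compound 2, whereas compound 1 sits within it. Among the compounds with values here, the only single-place step so far is a number 0.25 log units lower from compound 1 to compound 2 (within the scatter).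

Compound 4 `C[C@H](C(=O)O)c1nn(Cc2cn3cc(OCC4CC4)c(Cl)cc3n2)c2ccccc2c1=O` is the next point: 1-carboxyethyl in place of 1-carboxycyclopropyl on an aromatic carbon. The step from compound 1 to compound 2 is the one that bears on this, since it also exchanges the alkyl part of the acid-bearing arm, and it stayed within the scatter. Removing a carbon from compound 1 and moving from ring to open chain relative to compound 2 point in opposite directions, so for this assay no step beyond the scatter is expected: a number 0.01 log units lower from compound 2 to compound 4 (within the scatter). Compound 4 is therefore estimated at 2.45, with a range from 2.1 to 2.8.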

Compound 4, distribution coefficient: 2.39
Estimate against measurement, compound 4: 0.06 log units above, within the range that was stated.
By their numbers in this assay, from the lowest: compounds 4, 2, 1 and 3 (each within the scatter of the next, the first and the last beyond it).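

Within the data shown here, exchanging 1-carboxypropyl for 1-carboxyethyl on this aromatic carbon gives a number 0.32 log units lower from compound 1 to compound 4 (beyond the scatter) in this assay, the first step at this position to pass the scatter, so a change confined to the alkyl part of the acid-bearing arm can register on this read-out. Exchanging 1-carboxycyclopropyl for 1-carboxyethyl, which removes the three-membered ring, goes from 6 heavy atoms to 5 and brings in a defined stereocentre, gives a number 0.07 log units lower from compound 2 to compound 4 (within the scatter), so these two arms are not told apart in this assay. No measurement at hand accounts for the size of either step.

The compounds shown leave open how a carboxymethyl arm or a longer chain such as 1-carboxybutyl would read on this carbon, and so whether the difference between 1-carboxypropyl and 1-carboxyethyl extends to other chain lengths. Also open, from the compounds shown here alone, are the opposite configuration of the 1-carboxyethyl arm and the effect of putting a primary amide or a tetrazole in place of the carboxylic acid.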